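A 4-methylphenyl group gives way to 4-chloro-3-fluorophenyl

The compounds below may be only part of what the source reports. "The series", "measured", "known", "first", "only" and "open" are said of these compounds alone.

Going by the values given here, in an ADME assay on MDCK cells (Canis lupus familiaris) for cytotoxicity, read by CCK-8 assay, with a stated time of 72 h (a lower number here means a stronger inhibitor, a higher number a weaker inhibitor), compound 1 (`Cc1ccc(/C=C/C(=N/NC(N)=S)c2nc3ccccc3[nH]2)cc1`) reads 3.7 ug/mL and holds the higher of the two numbers measured so far. Compound 2 (`NC(=S)N/N=C(/C=C/c1cccc2[nH]ccc12)c1nc2ccccc2[nH]1`) reads 0.91 ug/mL and the gap between the two lies beyond the usual scatter of repeat measurements. Compound 3 (`NC(=S)N/N=C(/C=C/c1ccc(Cl)c(F)c1)c1nc2ccccc2[nH]1`) has not yet been measured. It carries 4-chloro-3-fluorophenyl in place of 4-methylphenyl on a double-bonded chain carbon bound to a double-bonded chain carbon. Among the compounds with values here, no measured pair shows what this swap does, so any expectation is cautious and stays close to the starting value. In this assay a small downward step is expected (a 1.5-fold lower number from compound 1 to compound 3 (0.17 log units; within the scatter)) and it should stay within the usual scatter. Compound 3 is estimated at 2.5 ug/mL (expected range 0.8 ug/mL to 7 ug/mL).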

Compound 3, half-maximal inhibitory concentration: 1.5 ug/mL
Compound 3: middle estimate off by 1.7-fold (0.22 log units), on the high side; measured number inside the range.
By their numbers in this assay, from the lowest: compounds 2 and 3 (each within the scatter of the next); then compound 1.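

In this assay, placing 4-chloro-3-fluorophenyl in place of 4-methylphenyl on a double-bonded chain carbon bound to a double-bonded chain carbon gives a 2.5-fold lower number from compound 1 to compound 3 (0.39 log units; beyond the scatter), the first step read at this place, and it shows that the number responds to a change in this group. The two groups count the same, with 0 hydrogen-bond donors, 0 hydrogen-bond acceptors and no net charge, so the step comes without any change in those counts. No measurement at hand accounts for the step.

From the compounds shown here alone, the swap removes the methyl and brings in chlorine and fluorine at once, so the share of each stays open, and a plain 4-chlorophenyl or 3-fluorophenyl group would help to separate them. Going by these compounds, how a phenyl ring carrying an amine or a carboxylic acid would read at this place also remains open.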